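The source may report more compounds than this note shows. Statements on the series, on what has been measured and on what is new or still open speak of the compounds shown alone.

Compounds that differ only in the fluorinated methoxyphenyl group on the shared core give little to work with in an ADME assay on a cell-free system (plasma, Homo sapiens) for protein binding; a lower number here means a smaller unbound share, a higher number a larger unbound share of the compound. Compound 3 `COc1c(C2CCN(c3ccn4c(CC5CC5)nnc4c3Cl)CC2)ccc(F)c1F` gives < 0.01, which is a limit of the assay and not a number. Compound 1 `COc1ccc(F)cc1C1CCN(c2ccn3c(CC4CC4)nnc3c2Cl)CC1` gives < 0.01, also a limit. Compound 2 `COc1c(F)cccc1C1CCN(c2ccn3c(CC4CC4)nnc3c2Cl)CC1` gives < 0.01, again a limit. The whole set therefore stands in one place: the limit of < 0.01 in this assay, at which 3 of the 3 values shown sit.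

Compound 4 `COc1ccc(F)c(F)c1C1CCN(c2ccn3c(CC4CC4)nnc3c2Cl)CC1` has the same atoms as compound 3, joined differently: 2,3-difluoro-6-methoxyphenyl in place of 3,4-difluoro-2-methoxyphenyl on a saturated ring carbon. In words, 2,3-difluoro-6-methoxyphenyl replaces 3,4-difluoro-2-methoxyphenyl on a saturated ring carbon.

Within the data shown here, three measured steps bear on this change, since each also alters this aromatic group: a step that the two limits leave unreadable from compound 1 to compound 2, a step that the two limits leave unreadable from compound 1 to compound 3 and a step that the two limits leave unreadable from compound 2 to compound 3. None of them has a readable size, so none offers a number to carry over to the new arrangement.

The only anchor for an expectation is compound 3 with its limit of < 0.01. No change beyond the usual scatter is expected in either direction, and the expected step is a step that the limit leaves unreadable from compound 3 to compound 4. The estimate for compound 4 is 0.005, with an expected range from 0.002 to 0.012, and this assay may well report only a limit again.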

Compound 4, unbound fraction: < 0.01
Compound 4 gave a limit, no number; the forecaster's own chance of this, stated with the estimate: 85%; the middle value lies beyond the limit too.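

Compound 4 gives < 0.01 in this assay (a limit, not a number). Among these compounds, no step from compound 1, compound 2 or compound 3 to compound 4 can be read, as all four compounds share one limit: the limit of < 0.01 in this assay, at which 4 of the 4 values shown sit. Going by these compounds, how far the unbound fractions of these four compounds differ, if at all, stays open.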